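Methoxy to Fluoro on the Longer Linker

The compounds below may be only part of what the source reports. "The series", "measured", "known", "first", "only" and "open" are said of these compounds alone.

Compound 1, `COc1ccc(CN(CCN2CCN(CCCc3ccccc3)CC2)c2ccccn2)cc1`: 6.57
Compound 2, `Fc1ccc(CN(CCN2CCN(CCCc3ccccc3)CC2)c2ccccn2)cc1`: 6.24
Compound 3, `COc1ccc(CN(CCCN2CCN(CCCc3ccccc3)CC2)c2ccccn2)cc1`: 7.08

All three were tested in an assay on HEK293 cells for inhibition of sodium-dependent dopamine transporter (Homo sapiens); a higher number here means a more potent compound, by a factor of ten per unit of this negative logarithm, a lower number a less potent compound. Compound 3 gives the highest number of the three, beyond the scatter in each comparison. Compound 1 and compound 2 share one core and differ by fluoro in place of methoxy on an aromatic carbon, a change that gave a number 0.33 log units lower from compound 1 to compound 2 (beyond the scatter). How the core of compound 1 differs from the core of compound 3 is not broken down here.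

Compound 4, `Fc1ccc(CN(CCCN2CCN(CCCc3ccccc3)CC2)c2ccccn2)cc1`, is still unmeasured. It differs from compound 3 by fluoro in place of methoxy on an aromatic carbon, the same change as from compound 1 to compound 2, at the same kind of place. A similar step is therefore expected, namely a number 0.33 log units lower from compound 3 to compound 4 (beyond the scatter), resting on a number 0.33 log units lower from compound 1 to compound 2 (beyond the scatter) in this assay. Compound 4 is estimated at 6.75, with a likely range from 6.3 to 7.2.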

Compound 4, logarithm of the reciprocal of the active concentration, log(1/C): 6.91
Compound 4: the middle estimate sits 0.16 log units below what was measured; measured number inside the range.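

On the second core, the same swap of methoxy for fluoro gave a number 0.17 log units lower from compound 3 to compound 4 (within the scatter). Set beside the earlier step, the change carried from one core to the other with no gap that can be told from the scatter: the same change on two cores in this assay, a number 0.33 log units lower (beyond the scatter) from compound 1 to compound 2 and a number 0.17 log units lower (within the scatter) from compound 3 to compound 4, 0.16 log units apart, within the scatter of two such steps. Among the compounds shown here, this shows that the two steps agree in this assay, but with only two pairs it does not show that the step has one fixed size across the series, and the second step alone is too small to tell from repeat scatter.

Still open, from the compounds shown here alone, is how other groups on the same aromatic carbon, such as chloro, trifluoromethyl or an amine, would compare. Also open, going by these compounds, is whether the swap behaves alike on a core with a longer chain.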